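The source may report more compounds than this note shows. Statements on the series, on what has been measured and on what is new or still open speak of the compounds shown alone.

Measured so far:
compound 1 `CCN(C(=O)c1ccccc1OCc1ccccc1)[C@@H]1CCC[C@H](NC(C)=O)C1` — in an assay on HEK293 cells for inhibition of transient receptor potential cation channel subfamily M member 8 (Homo sapiens), read by FLIPR and calcium flux (a lower number here means a stronger inhibitor, a higher number a weaker inhibitor), compound 1 gives > 5000 nM, which is a limit of the assay.
compound 2 `CCN(C(=O)c1ccccc1OCc1ccccc1)[C@@H]1CC[C@H](N)C1` — in this assay compound 2 gives > 5000 nM, again a limit of the assay.

Compound 2 therefore stands nowhere on a numerical scale: its value is a limit only, and the same holds for compound 1, both sitting at the limit of > 5000 nM in this assay, at which 2 of the 2 values shown sit. Within the data shown here, with two limits, no step between compound 1 and compound 2 can be sized and the two cannot be ordered.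

Compound 3 `CCN(C(=O)c1ccccc1OCc1ccccc1)[C@@H]1CC[C@@H](N)C1` keeps every atom and bond of compound 2; the only difference is the two compounds have the same atoms and bonds and differ only in configuration as drawn: 1 of 2 stereo elements differ; a stereocentre at a saturated ring carbon is drawn S in compound 2 and R in compound 3. Among the measured compounds shown here, no measured pair here shows what a change of configuration alone does in this assay, so the direction and size of the step are open; the plain expectation is that compound 3 will again report a limit, with a real number less likely. Compound 3 is estimated at 8000 nM, with a range from 1500 nM to 40000 nM. The expected step from compound 2 to compound 3 is a step that the limit leaves unreadable from compound 2 to compound 3, which is to be read as no movement that the assay would resolve.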

Compound 3, antagonist equilibrium constant: 2600 nM
Compound 3: middle estimate off by 3.1-fold (0.49 log units), on the high side; low and high end bracket the measured number.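

In this assay, among these compounds, compound 3 gives 2600 nM, the first real number, so the series can now be read on a numerical scale at this amine. The change of configuration at one saturated ring carbon comes with an at least 1.9-fold lower number from compound 2 to compound 3 (0.28 log units; that floor lies within the scatter), so only a floor on the step is known, and that floor alone does not establish a difference beyond repeat measurement. The number appears with no atom or bond exchanged: the fact that compounds 2 and 3 differ only in the configuration as drawn.

Still open, from the compounds shown here alone, is what the other stereocentre contributes, since only one of the two stereo elements differs in this pair. Also open, going by these compounds, is whether a carboxylic acid or a dimethylamino group in place of the amine, on the carbon configured as in compound 3, would hold, gain or lose this reading.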